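The source may report more compounds than this note shows. Statements on the series, on what has been measured and on what is new or still open speak of the compounds shown alone.

In an assay for inhibition of Receptor tyrosine-protein kinase erbB-3 variant L858R (Homo sapiens), read by mobility shift assay, with a stated time of 10 min (a lower number here means a stronger inhibitor, a higher number a weaker inhibitor), compound 2 `O=C(O)CCCC(=O)Nc1cc(Nc2ccccc2)ncn1` gives 183 nM, the lower of the two numbers recorded here. Compound 1 `O=C(Nc1cc(Nc2ccc(Cl)cc2)ncn1)c1ccc(F)cc1` gives 1610 nM, and the gap between the two lies beyond the usual scatter. Compound 3 `O=C(O)CCCC(=O)Nc1cc(Nc2ccc(Cl)cc2)ncn1` differs from compound 2 by chloro in place of hydrogen on an aromatic carbon. For the measured compounds named here, no measured pair isolates this single change, so its effect cannot be read from the data. The expected step is a 1.1-fold lower number from compound 2 to compound 3 (0.06 log units; within the scatter), small and with no direction that clearly exceeds the scatter. Compound 3 is therefore estimated at 160 nM, within a range from 50 nM to 500 nM.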

Compound 3, half-maximal inhibitory concentration: 1320 nM
Estimate against measurement, compound 3: 8.3-fold (0.92 log units) below; measured number outside the range, above it.
By their numbers in this assay, from the lowest: compound 2; then compounds 3 and 1 (each within the scatter of the next).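

In this assay, the change from phenyl to 4-chlorophenyl, with chloro entering para to a large group, gives a 7.2-fold higher number from compound 2 to compound 3 (0.86 log units; beyond the scatter) and so is not silent at this position. With 4-chlorophenyl kept, 3-carboxypropyl in place of 4-fluorophenyl on the carbonyl carbon gives a 1.2-fold lower number from compound 1 to compound 3 (0.09 log units; within the scatter) and does not separate the two compounds. Nothing shown here accounts for the chloro step. Going by these compounds, whether fluoro, methyl or methoxy at this position would act as chloro does stays open. So does whether 4-fluorophenyl on the carbonyl carbon would match compound 2 when paired with plain phenyl.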